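A few compounds are considered here, and "the series" means these few. Any claim that something is new, unique, unknown or untested is made for them only; others in the source may bear on it.

Measured in a functional assay on HL-60 cells (Homo sapiens) for inhibition, read by MTT assay, with a stated time of 48 h, tested at 10 uM; a lower number here means less inhibition of growth, a higher number more inhibition of growth at the concentration tested:
- compound 1 `Cc1cc(=O)c2c(O)c(CN3CC(O)CC3C(=O)O)c(O)c([C@H]3CCN(C)C[C@H]3O)c2o1`: 28%
- compound 2 `Cc1oc2c([C@H]3CCN(C)C[C@H]3O)c(O)cc(O)c2c(=O)c1C(O)c1ccc([N+](=O)[O-])cc1`: 0%

Of these two, compound 2 stands lowest, and the gap up to compound 1, its nearest neighbour, lies beyond the scatter. Among the compounds with values here, the two differ in more than one place, so no single-change step is available to guide the next reading. Compound 3 `Cc1oc2c([C@H]3CCN(C)C[C@H]3O)c(O)cc(O)c2c(=O)c1C(O)c1ccc(Cl)cc1` has chloro in place of nitro on an aromatic carbon, para to a large group: chloro in place of nitro on an aromatic carbon. In this assay, a small rise is expected, probably not beyond the scatter, because compound 2 reads 0%. The estimated change is a number 8 percentage points higher from compound 2 to compound 3 (within the scatter). For compound 3 the expected value is 8%, with an estimated range of 0% to 28%.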

Compound 3, percent growth inhibition at one concentration: 2%
The estimate for compound 3 lay 6 percentage points above the measured number, within the range that was stated.
By their numbers in this assay, from the lowest: compounds 2 and 3 (each within the scatter of the next); then compound 1.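

In this assay, chloro in place of nitro on the aromatic carbon gives a number 2 percentage points higher from compound 2 to compound 3 (within the scatter), so the two readings cannot be told apart. Within the data shown here, this is the first single-change step, and it shows that, at this position para to a large group, this exchange does not separate the two compounds. No supporting data bear on this result.

On these data alone, whether an amine or a methoxy group at the same position would give a different reading remains open. So does the effect of a change elsewhere on the shared core.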